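The compounds below may be only part of what the source reports. "The series", "measured", "known", "first", "only" and "open" are said of these compounds alone.

Measured so far in a functional assay on HeLa cells (Homo sapiens) for antiproliferative activity, with a stated time of 48 h; a lower number here means a stronger inhibitor, a higher number a weaker inhibitor:
compound 1 `C=C(Br)C(=O)Nc1ccc(C(=O)/C=C/c2ccc(OC)cc2)cc1` gives 310 nM;
compound 2 `C=C(Br)C(=O)Nc1ccc(C(=O)/C=C/c2ccc(OC)cc2OC)cc1` gives 1100 nM;
compound 3 `Nc1ccc(/C=C/C(=O)c2ccccc2)cc1` gives 36000 nM.

Compound 1 and compound 2 differ in a single place, (methoxy in place of hydrogen on an aromatic carbon), and that change brought a 3.5-fold higher number from compound 1 to compound 2 (0.55 log units; beyond the scatter). Compound 3 carries a different core from compound 1; how the two cores differ is not broken down here, and compound 3 stands far apart from both, with the highest number of the three.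

Compound 4 `COc1cccc(C(=O)/C=C/c2ccc(N)cc2)c1` has not yet been measured. It differs from compound 3 by methoxy in place of hydrogen on an aromatic carbon. This is the same kind of change as that from compound 1 to compound 2, but not the same: in compound 2 the new group sits ortho to a large group and meta to a methoxy group, while in compound 4 it sits meta to a large group, on a core that is itself different.

In this assay, among the compounds with values here, the step from compound 3 to compound 4 is expected to be a 1.3-fold higher number from compound 3 to compound 4 (0.10 log units; within the scatter), a small one, because the only measured example of this group entering, a 3.5-fold higher number from compound 1 to compound 2 (0.55 log units; beyond the scatter), was modest, and the surroundings here are not alike. Compound 4 is therefore estimated at about 45000 nM, between 15000 nM and 130000 nM.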

Compound 4, half-maximal inhibitory concentration: 33000 nM
Compound 4: the middle estimate sits 1.4-fold (0.13 log units) above what was measured; low and high end bracket the measured number.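

In this assay, putting a methoxy group on the core of compound 3 gave a 1.1-fold lower number from compound 3 to compound 4 (0.04 log units; within the scatter), a step within the usual scatter. On these two cores, the same kind of change did not give the same result: the same change on two cores in this assay, a 3.5-fold higher number (0.55 log units; beyond the scatter) from compound 1 to compound 2 and a 1.1-fold lower number (0.04 log units; within the scatter) from compound 3 to compound 4, 3.9-fold (0.59 log units) apart, beyond the scatter of two such steps. This shows that the step seen in the first pair cannot simply be carried over to the second, but it does not show what sets them apart: the two pairs differ both in their core and in where the methoxy group sits, and each step rests on a single pair of compounds.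

The compounds shown leave open what a methoxy group would do on the core of compound 1 at the place it holds in compound 4, which would help separate the effect of the core from that of the position. They also leave open how other groups at that place on the core of compound 3, such as a hydroxyl or an ethoxy group, would compare.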